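Replacing the phenyl group of compound 3

The compounds below may be only part of what the source reports. "The series", "measured", "known", "first", "only" and "open" are said of these compounds alone.

In a functional assay on HCT-116 cells (Homo sapiens) for antiproliferative activity, read by MTT assay, with a stated time of 48 h (on this read-out higher numbers stand for weaker inhibition and lower numbers for stronger inhibition), compound 1 `COc1ccc(-c2cncc3[nH]c(=O)n(Cc4cc(OC)c(OC)c(OC)c4)c23)cc1` reads > 20000 nM as a limit of the assay and not as a number. Compound 2 `COc1ccc(-c2nc3cnccc3n2-c2cc(OC)c(OC)c(OC)c2)cc1O` also reads > 20000 nM as a limit only. Among the measured compounds shown here, compound 3 `COc1ccc(-c2cc3c(cn2)[nH]c(=O)n3-c2cc(OC)c(OC)c(OC)c2)cc1O` gives 340 nM as the only true number of the three. Compound 4 `CCOc1ccc(-c2cc3c(cn2)[nH]c(=O)n3-c2cc(OC)c(OC)c(OC)c2)cc1F` has not been measured yet. It carries 4-ethoxy-3-fluorophenyl in place of 3-hydroxy-4-methoxyphenyl on an aromatic carbon of the shared core. For the measured compounds named here, no measured pair shows this exchange, so any forecast stays loose. The expected step of a 2.6-fold higher number from compound 3 to compound 4 (0.42 log units; beyond the scatter) is a moderate move towards weaker inhibition in this assay and beyond the usual scatter. Compound 4 is estimated at 900 nM with 120 nM to 7000 nM as the expected range.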

Compound 4, half-maximal inhibitory concentration: 7220 nM
Estimate against measurement, compound 4: 8.0-fold (0.90 log units) below; measured number above the stated range.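

In this assay, the group on this aromatic carbon of the shared core matters strongly, since 4-ethoxy-3-fluorophenyl in place of 3-hydroxy-4-methoxyphenyl gives a 21-fold higher number from compound 3 to compound 4 (1.33 log units; beyond the scatter). Among the compounds shown here, this is the first readable step at this position, and it shows that not every substituted phenyl group is tolerated there. Compound 4 still gives a true number, so the loss stops short of the end of the scale: the limit of > 20000 nM in this assay, at which 2 of the 4 values shown sit.

The exchange changes two substituents at once, so the compounds shown cannot separate the loss of hydroxy from the gain of ethoxy and fluorine. On these data alone, whether an amine on this phenyl ring would restore inhibition also remains open.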